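Swapping benzyl for tert-butyl on a nitrone nitrogen

A few compounds are considered here, and "the series" means these few. Any claim that something is new, unique, unknown or untested is made for them only; others in the source may bear on it.

Measured so far:
compound 1, `[O-]/[N+](=C\c1cn(-c2ccc(F)cc2)nn1)Cc1ccccc1` — > 100000 nM (a limit)
compound 2, `[O-]/[N+](=C\c1cn(-c2ccc(C(F)(F)F)cc2)nn1)Cc1ccccc1` — > 100000 nM (a limit)

In a functional assay on COLO 205 cells (Homo sapiens) for inhibition, read by MTT assay, with a stated time of 24 h (a lower number here means a stronger inhibitor, a higher number a weaker inhibitor), compound 1 gives > 100000 nM, which is a limit of the assay and not a number. Compound 2 likewise gives > 100000 nM, also a limit. The step that the two limits leave unreadable from compound 1 to compound 2 is therefore unreadable, and both values sit at the limit of > 100000 nM in this assay, at which 2 of the 2 values shown sit. Among the measured compounds shown here, compound 1 thus stands only at a limit, as does the one further value shown.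

Compound 3, `CC(C)(C)/[N+]([O-])=C/c1cn(-c2ccc(F)cc2)nn1`, differs from compound 1 by tert-butyl in place of benzyl on a double-bonded nitrogen. For the measured compounds named here, no measured step touches this position; the only measured step, which changes the aromatic substituent, cannot be sized. Compound 1 offers no number to start from. Compound 3 is therefore expected to give 100000 nM, with a range from 30000 nM to 300000 nM, most likely again reported as a limit. The expected step of a number no higher from compound 1 to compound 3 (the limit leaves the size open) is essentially none beyond the scatter.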

Compound 3, half-maximal inhibitory concentration: 58900 nM
Estimate against measurement, compound 3: 1.7-fold (0.23 log units) above, within the range that was stated.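

In this assay compound 3 gives 58900 nM, the first value shown that is a number and not a limit. Tert-butyl in place of benzyl on a double-bonded nitrogen gives an at least 1.6-fold lower number from compound 1 to compound 3 (0.22 log units; that floor lies within the scatter), so this is the one change shown that yields a readable value, though the true size of the step stays open. Compound 1 and compound 2 could not show this, and the step between them cannot be read, since both stand at a limit: the limit of > 100000 nM in this assay, at which 2 of the 3 values shown sit.

The compounds shown leave open whether another group on that nitrogen, such as cyclohexyl or a chain ending in an amine, would lower the number further. They also leave open whether trifluoromethyl in place of fluoro would change the number when tert-butyl is present.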